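A few compounds are considered here, and "the series" means these few. Any claim that something is new, unique, unknown or untested is made for them only; others in the source may bear on it.

Measured in a functional assay on SH-SY5Y cells (Homo sapiens) for cytotoxicity, read by MTT assay, with stated times of 1 h and 24 h; a higher number here means that more compound is needed for the effect, a lower number that less compound is needed:
- compound 1 `CN(C)CCC(=O)c1cc2ccc(O)cc2oc1=O`: > 100000 nM (a limit of the assay, not a number)
- compound 2 `O=C(CCN1CCCCC1)c1cc2ccc(O)cc2oc1=O`: 45400 nM
- compound 3 `Cc1cc(O)cc2oc(=O)c(C(=O)CCN(C)C)cc12`: 25700 nM

Compound 3 at 25700 nM lies within the scatter of compound 2 at 45400 nM. Compound 4 `Cc1cc(O)cc2oc(=O)c(C(=O)CCN3CCCC3)cc12` differs from compound 3 as follows: pyrrolidin-1-yl in place of dimethylamino on a saturated chain carbon, two bonds along the chain from a carbonyl carbon.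

The nearest measured exchange of dimethylamino for a ring is an at least 2.2-fold lower number from compound 1 to compound 2 (0.34 log units; beyond the scatter). On these data alone, that step starts from a limit, so its full size is unknown. The other step, an at least 3.8-fold lower number from compound 1 to compound 3 (0.59 log units; beyond the scatter), concerns the methyl that compound 3 and compound 4 share, so it bears only indirectly.

A step of similar size toward a lower number in this assay is expected, and the estimated step is a 2.1-fold lower number from compound 3 to compound 4 (0.33 log units; beyond the scatter). For compound 4 the estimated value is 12000 nM, with an expected range of 5000 nM to 32000 nM.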

Compound 4, half-maximal effective concentration: > 100000 nM
Compound 4: no number, only a limit; the forecaster's own chance of this, stated with the estimate: 3%; middle value at least 8.3-fold (0.92 log units) from the limit.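

In this assay, pyrrolidin-1-yl in place of dimethylamino on the methyl-bearing core gives an at least 3.8-fold higher number from compound 3 to compound 4 (0.59 log units; beyond the scatter), opposite in direction to an at least 2.2-fold lower number from compound 1 to compound 2 (0.34 log units; beyond the scatter) with piperidin-1-yl on the core without the methyl. A ring on this chain carbon therefore gives no single direction across the compounds shown. Compound 4 gives only a limit of the assay, not a number, and the full size of its step stays unknown: the limit of > 100000 nM in this assay, at which 2 of the 4 values shown sit.

Open, on these data alone, is whether the direction follows ring size or the presence of the methyl. Piperidin-1-yl combined with the methyl, or morpholin-4-yl on the same chain carbon, would bear on this.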